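Hept-1-yn-1-yl for cyanosulfanyl on a deoxyuridine core

This account rests on a few compounds, and the source may have more. Where it says the series, first, only, none or still open, it means among the compounds named here.

Of the compounds shown here, three have been tested in an ADME assay on L1210/0 cells (Mus musculus) for cytotoxicity, with a stated time of 48 h; on this read-out higher numbers stand for weaker inhibition and lower numbers for stronger inhibition. Compound 1 `N#CSc1cn([C@H]2C[C@H](O)[C@@H](CO)O2)c(=O)[nH]c1=O` gives 78900 nM in this assay and is the only compound of the three for which a number rather than a limit is shown. Compound 2 `CC1(C)C(CO)CC1Cn1nnc2c(N)nc(N)nc21` reaches only the limit of this assay, at > 200000 nM. Compound 3 `COc1nc(I)nc2c1ncn2COCCO` likewise sits at the limit, > 200000 nM. Thus the limit of > 200000 nM in this assay, at which 2 of the 3 values shown sit, marks where two of the three values stand, and compound 1 is the sole reference point for any further step.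

Compound 4 `CCCCCC#Cc1cn([C@H]2C[C@H](O)[C@@H](CO)O2)c(=O)[nH]c1=O` is not yet measured. It differs from compound 1 in one place: hept-1-yn-1-yl in place of cyanosulfanyl on an aromatic carbon. Going by the values given here, no step between two measured compounds is available, so the expected size of this change in this assay rests on compound 1 alone. The step from compound 1 to compound 4 is expected to move toward stronger inhibition by a 2.0-fold lower number from compound 1 to compound 4 (0.30 log units; within the scatter), though a change no larger than the usual scatter would not be surprising. Compound 4 is therefore estimated at 40000 nM in this assay, within a range from 5000 nM to 200000 nM.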

Compound 4, half-maximal inhibitory concentration: > 200000 nM
Compound 4 gave a limit, no number (the forecaster's own chance of this, stated with the estimate: 25%); middle value at least 5.0-fold (0.69 log units) away from the limit.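

On the shared core, the aromatic carbon two atoms from the ring nitrogen proves sensitive to its substituent in this assay: hept-1-yn-1-yl in place of cyanosulfanyl gives an at least 2.5-fold higher number from compound 1 to compound 4 (0.40 log units; beyond the scatter). Compound 4 gives a limit and not a number, so this step is a lower bound and its full size cannot be read. Going by these compounds alone, compound 1 thus remains the only compound with a number, and the new result adds to those at the top of the read-out: the limit of > 200000 nM in this assay, at which 3 of the 4 values shown sit.

The compounds shown leave open how a shorter chain such as prop-1-yn-1-yl, or an amine, on this aromatic carbon would compare with compound 1. From the compounds shown here alone, with only cyanosulfanyl and hept-1-yn-1-yl seen at this place, it also remains open whether any group here gives a lower number than compound 1.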